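A 3,5-dichlorophenyl swap in a flat series

A few compounds are considered here, and "the series" means these few. Any claim that something is new, unique, unknown or untested is made for them only; others in the source may bear on it.

In a functional assay on SW-620 cells (Homo sapiens) for cytotoxicity, read by MTT assay, with a stated time of 72 h (on this read-out lower numbers stand for stronger inhibition and higher numbers for weaker inhibition), compound 1 (`COc1cccc(/C=C2\CCC/C(=C\c3cccc(Cl)c3)C2=O)c1OC`) gives 9100 nM, compound 2 (`COc1cccc(/C=C2\CCC/C(=C\c3ccccc3Br)C2=O)c1OC`) gives 12100 nM and compound 3 (`COc1ccc(/C=C2\CCC/C(=C\c3cccc(OC)c3OC)C2=O)cc1`) gives 13600 nM. Compound 3 thus stands level with the other two, with all three values within the scatter of one another.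

Compound 4 (`COc1cccc(/C=C2\CCC/C(=C\c3cc(Cl)cc(Cl)c3)C2=O)c1OC`) differs from compound 3 in one group: 3,5-dichlorophenyl in place of 4-methoxyphenyl on a double-bonded chain carbon bound to a double-bonded ring carbon. The change places 3,5-dichlorophenyl in place of 4-methoxyphenyl on a double-bonded chain carbon bound to a double-bonded ring carbon.

All three measured steps fall at this same place: a 1.3-fold higher number from compound 1 to compound 2 (0.12 log units; within the scatter), a 1.5-fold higher number from compound 1 to compound 3 (0.17 log units; within the scatter) and a 1.1-fold higher number from compound 2 to compound 3 (0.05 log units; within the scatter). Each lies within the scatter. Going by the values given here, compound 1 is the closest precedent, as its group also carries chlorine, but no measured compound carries two chlorines. No step beyond the scatter is therefore expected in this assay.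

The expected step is a 1.5-fold lower number from compound 3 to compound 4 (0.18 log units; within the scatter). For compound 4 the estimated value is 9000 nM, with an expected range of 4000 nM to 18000 nM.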

Compound 4, half-maximal inhibitory concentration: 5500 nM
Beside the measured number, compound 4's estimate is 1.6-fold (0.21 log units) above it; measured number inside the range.
By their numbers in this assay, from the lowest: compounds 4, 1, 2 and 3 (each within the scatter of the next, the first and the last beyond it).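

In this assay the place on a double-bonded chain carbon bound to a double-bonded ring carbon now gives steps beyond the scatter, which no earlier swap there did: 3,5-dichlorophenyl brings a 2.5-fold lower number from compound 3 to compound 4 (0.39 log units; beyond the scatter) and a 2.2-fold lower number from compound 2 to compound 4 (0.34 log units; beyond the scatter) as modest steps. The added chloro in place of hydrogen on an aromatic carbon gives only a 1.7-fold lower number from compound 1 to compound 4 (0.22 log units; within the scatter) within the scatter, so compound 4 separates from compound 3 and compound 2 but not from its closest relative, compound 1. No measurement at hand gives a cause for these steps.

Still open, on these data alone, is whether the steps depend on chlorine, or would also appear with 3,5-difluorophenyl or 3,5-dimethoxyphenyl. Also open, as far as these compounds go, is how a pyridyl group or a phenyl carrying a carboxylic acid would read in this assay at this place.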